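Swapping Methoxy for Cyano on a Shared Core

The source may report more compounds than this note shows. Statements on the series, on what has been measured and on what is new or still open speak of the compounds shown alone.

Compound 1 `COc1cccc(OCc2cc(C)nc(-c3ccccn3)n2)c1` and compound 3 `Cc1cc(COc2cccc(C#N)c2)nc(-c2ccccn2)n1` differ in a single group: cyano in place of methoxy on an aromatic carbon. In a physicochemical assay for lipophilicity, at pH 7.4 (a lower number here means a more polar compound, a higher number a more lipophilic compound), compound 1 gives 2.9, and compound 3 gives 2.7; the step is a number 0.20 log units lower from compound 1 to compound 3 (within the scatter). Compound 2 `COc1ccc(OCc2cc(C)nc(-c3ccccn3)n2)cc1` is built from the same atoms as compound 1, joined differently; the difference between the two cores is not broken down here. In this assay compound 2 gives 2.8. Compound 4 `Cc1cc(COc2ccc(C#N)cc2)nc(-c2ccccn2)n1` has not yet been measured and arises from compound 2 by cyano in place of methoxy on an aromatic carbon, the same kind of change, the group now sitting para to a large group rather than meta to a large group. Because a number 0.20 log units lower from compound 1 to compound 3 (within the scatter), a similar step is expected here, a number 0.20 log units lower from compound 2 to compound 4 (within the scatter). Compound 4 is therefore estimated at 2.6, most likely between 2.3 and 2.9.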

Compound 4, distribution coefficient: 2.6
Compound 4: middle estimate and measured number agree at the digits printed; the measured number falls inside the stated range.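

In this assay the step for cyano in place of methoxy with the group para to a large group is a number 0.20 log units lower from compound 2 to compound 4 (within the scatter), the same printed size as a number 0.20 log units lower from compound 1 to compound 3 (within the scatter), so the change carried across with no difference in size in these two pairs. Both steps lie within the scatter, so they do not show that this change truly moves the number, and two pairs make no rule for the whole series. Nothing measured here explains why the two steps match.

Still open, on these data alone, is how an amine or a carboxylic acid on the same aromatic carbon would compare with methoxy and cyano. Also open, as far as these compounds go, is whether the same step would appear on other cores.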